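This account rests on a few compounds, and the source may have more. Where it says the series, first, only, none or still open, it means among the compounds named here.

Measured in a functional assay on U-251 cells (Homo sapiens); on this read-out higher numbers stand for weaker inhibition of growth and lower numbers for stronger inhibition of growth:
- compound 1 `O=S(=O)(/C=C/c1ccccc1)Cc1ccc(Nc2ncnc3ccccc23)cc1`: > 100000 nM (a limit of the assay, not a number)
- compound 2 `O=S(=O)(/C=C/c1ccc(Cl)cc1)Cc1ccc(Nc2ncnc3ccccc23)cc1`: 49000 nM
- compound 3 `O=S(=O)(/C=C/c1ccc(Cl)cc1Cl)Cc1ccc(Nc2ncnc3ccccc23)cc1`: 4000 nM

For the measured compounds named here, compound 2 holds the higher of the two true numbers, and the gap to its only numerical neighbour is a 12-fold lower number from compound 2 to compound 3 (1.09 log units; beyond the scatter). Compound 4 `O=S(=O)(/C=C/c1ccc(Cl)cc1)Cc1ccc(Nc2ncnc3ccc(Br)cc23)cc1` keeps all of compound 2 except for one change: bromo in place of hydrogen on an aromatic carbon.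

Going by the values given here, no measured step adds bromo, so the nearest guides are the chloro additions. The first gave an at least 2.0-fold lower number from compound 1 to compound 2 (0.30 log units; that floor lies within the scatter), the second gave a 12-fold lower number from compound 2 to compound 3 (1.09 log units; beyond the scatter), and the two together gave an at least 25-fold lower number from compound 1 to compound 3 (1.39 log units; beyond the scatter). Those chloro groups sit on the phenyl group, whereas the bromo enters the fused or bridged system of two rings, so they guide only loosely. A moderate move towards stronger growth inhibition in this assay is therefore expected, smaller than the second chloro step. The expected change is a 4.1-fold lower number from compound 2 to compound 4 (0.61 log units; beyond the scatter). For compound 4 the estimated value is 12000 nM, with an expected range of 3000 nM to 50000 nM.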

Compound 4, concentration for 50% growth inhibition: 30000 nM
Beside the measured number, compound 4's estimate is 2.5-fold (0.40 log units) below it; low and high end bracket the measured number.
By their numbers in this assay, from the lowest: compound 3; then compounds 4 and 2 (each within the scatter of the next). At a limit, above all of these: compound 1.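

In this assay, placing bromo on an aromatic carbon of the fused or bridged system of two rings gives a 1.6-fold lower number from compound 2 to compound 4 (0.21 log units; within the scatter). This is the first change shown on that part of the molecule, and its effect differs from that of the second chloro addition on the phenyl group, which gives a 12-fold lower number from compound 2 to compound 3 (1.09 log units; beyond the scatter). Among the compounds shown, then, a clear gain in growth inhibition comes from the phenyl group, while this bromo leaves compound 4 indistinguishable from compound 2.

As far as these compounds go, whether an amine, a methoxy group or a carboxylic acid on the same carbon would do more remains open, as does the effect of this bromo when combined with the two chloro groups of compound 3. Compound 1 offers no firm baseline for such comparisons, because its value is a limit and not a number: the limit of > 100000 nM in this assay, at which 1 of the 4 values shown sits.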